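From dimethoxyphenyl to trimethoxyphenyl: compound 3 to compound 4

A few compounds are considered here, and "the series" means these few. Any claim that something is new, unique, unknown or untested is made for them only; others in the source may bear on it.

In a functional assay on 4T1 cells (Mus musculus) for cytotoxicity, read by MTT assay, with a stated time of 48 h (a higher number here means a weaker inhibitor, a lower number a stronger inhibitor), compound 1 (`COc1ccc(/C=C/C(=O)/C=C/c2cc3ccccc3nc2Oc2ccc(Br)cc2)cc1`) gives > 10000 nM as a limit of the assay and not a number. Compound 2 (`COc1ccc(/C=C/C(=O)/C=C/c2cc3ccccc3nc2Oc2ccc(Br)cc2)c(OC)c1`) gives > 10000 nM which is likewise a limit. Compound 3 (`COc1ccc(/C=C/C(=O)/C=C/c2cc3ccccc3nc2Oc2ccc(Br)cc2)cc1OC`) gives > 10000 nM which is again a limit. Within the data shown here, the series so far sits at the limit of > 10000 nM in this assay, at which 3 of the 3 values shown sit, and compound 3 has no number of its own.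

The measured steps are a step that the two limits leave unreadable from compound 1 to compound 2 and a step that the two limits leave unreadable from compound 1 to compound 3 and a step that the two limits leave unreadable from compound 2 to compound 3 so none of them offers a size or direction to carry forward.

Compound 4 (`COc1cc(OC)c(/C=C/C(=O)/C=C/c2cc3ccccc3nc2Oc2ccc(Br)cc2)c(OC)c1`) carries 2,4,6-trimethoxyphenyl in place of 3,4-dimethoxyphenyl on a double-bonded chain carbon bound to a double-bonded chain carbon.

With compound 3 at > 10000 nM as a limit, the data support no predicted move in either direction, and compound 4 is expected to remain weak in this assay and most likely to be reported only as a limit. The expected change is a step that the limit leaves unreadable from compound 3 to compound 4 and it carries the uncertainty of that limit. If a number is reported, the estimate for compound 4 is 15000 nM with an expected range from 6000 nM to 40000 nM around it.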

Compound 4, half-maximal inhibitory concentration: > 10000 nM
Compound 4: a limit, no number; the forecaster's own chance of this, stated with the estimate: 80%; the middle value does not contradict the limit.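

In this assay compound 4 gives > 10000 nM, a limit and not a number. Among these compounds, no step among compound 1, compound 2, compound 3 and compound 4 can be read, because all sit at a limit: the limit of > 10000 nM in this assay, at which 4 of the 4 values shown sit. The compounds shown leave open whether the number or placing of methoxy groups changes cytotoxicity at all.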